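The compounds below may be only part of what the source reports. "The series", "measured", "known", "first", "only" and "open" are said of these compounds alone.

Measured compounds:
compound 1, `C=C1[C@H](C)CCC[C@]1(C)CC/C(C)=C/CC1=C(O)C(=O)C=C(OC)C1=O`, 2.4 ug/mL
compound 2, `CC1=CCC[C@](C)(CC/C(C)=C/CC2=C(O)C(=O)C=C(N[C@@H](C(=O)O)[C@@H](C)O)C2=O)[C@@H]1C`, > 10 ug/mL
compound 3, `CC1=CCC[C@H]2[C@](C)(CC3=C(O)C(=O)C=C(N[C@@H](CO)C(=O)O)C3=O)[C@@H](C)CC[C@]12C`, 3.8 ug/mL

Three compounds have been examined in an ADME assay on L1210 cells (Mus musculus) for cytotoxicity, with a stated time of 48 h; on this read-out lower numbers stand for stronger inhibition and higher numbers for weaker inhibition. Compound 1 gives 2.4 ug/mL and compound 3 gives 3.8 ug/mL; these two numbers lie within the scatter of each other. Within the data shown here, compound 2 yields only a limit in this assay, > 10 ug/mL, so no number is known for it; it is the one compound of the three that sits at the limit of > 10 ug/mL in this assay, at which 1 of the 3 values shown sits. No step between measured compounds differing in one place is given, and compound 2 is the weakest inhibitor of the three on the numbers shown.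

The step considered runs from compound 2 to compound 4, `CC1=CCC[C@](C)(CC/C(C)=C/CC2=C(O)C(=O)C=C(N[C@H](C(=O)O)[C@@H](C)O)C2=O)[C@@H]1C`. The change is: the two compounds have the same atoms and bonds and differ only in configuration as drawn: 1 of 5 stereo elements differ; a stereocentre at a saturated chain carbon is drawn R in compound 2 and S in compound 4. Because compound 2 gives > 10 ug/mL, the change of configuration at one saturated chain carbon is expected to leave the value near that limit; the step from compound 2 to compound 4 is estimated as a step that the limit leaves unreadable from compound 2 to compound 4, none beyond the scatter. Compound 4 is therefore expected to give 12 ug/mL, in the range 4 ug/mL to 40 ug/mL.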

Compound 4, half-maximal inhibitory concentration: > 10 ug/mL
Compound 4 gave a limit, no number (the forecaster's own chance of this, stated with the estimate: 65%); the middle value does not contradict the limit.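

In this assay the step between compound 2 and compound 4 cannot be read, because both give only a limit and no number: the limit of > 10 ug/mL in this assay, at which 2 of the 4 values shown sit. The compounds shown leave open whether the configuration at this saturated chain carbon changes the value at all.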